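Phenyl group change from compound 3 to compound 4

This account rests on a few compounds, and the source may have more. Where it says the series, first, only, none or still open, it means among the compounds named here.

Values in a functional assay on A549 cells (Homo sapiens) for cytotoxicity, read by MTT assay, with a stated time of 72 h; a lower number here means a stronger inhibitor, a higher number a weaker inhibitor:
- compound 1 `O=C(/C=C/c1ccc([N+](=O)[O-])cc1)Nc1cc2c(Nc3ccc(F)c(Cl)c3)ncnc2cc1O[C@H]1CCOC1`: 12000 nM
- compound 2 `O=C(/C=C/c1cccc(Cl)c1Cl)Nc1cc2c(Nc3ccc(F)c(Cl)c3)ncnc2cc1O[C@H]1CCOC1`: 23200 nM
- compound 3 `COc1ccc(OC)c(/C=C/C(=O)Nc2cc3c(Nc4ccc(F)c(Cl)c4)ncnc3cc2O[C@H]2CCOC2)c1`: 7300 nM

The standing of compound 3 rests on two measured steps. One shows no separation: a 1.6-fold lower number from compound 1 to compound 3 (0.22 log units; within the scatter). The other shows a modest separation: a 3.2-fold lower number from compound 2 to compound 3 (0.50 log units; beyond the scatter). The remaining step, a 1.9-fold higher number from compound 1 to compound 2 (0.29 log units; within the scatter), also stays inside the scatter.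

Next in the series is compound 4 `COc1ccc(/C=C/C(=O)Nc2cc3c(Nc4ccc(F)c(Cl)c4)ncnc3cc2O[C@H]2CCOC2)c(OC)c1OC`, not yet measured in this assay. The change is 2,3,4-trimethoxyphenyl in place of 2,5-dimethoxyphenyl on a double-bonded chain carbon bound to a double-bonded chain carbon, with 2,3,4-trimethoxyphenyl in place of 2,5-dimethoxyphenyl on a double-bonded chain carbon bound to a double-bonded chain carbon.

All three measured steps exchange the phenyl group at this same place, and the largest of them is only modest. None of them tests a 2,3,4-trimethoxyphenyl group, so the evidence is indirect. For the measured compounds named here, the nearest reference is compound 3 at 7300 nM, the only measured compound that also carries methoxy groups. No change beyond the scatter is expected, and the estimated step is a 1.2-fold higher number from compound 3 to compound 4 (0.09 log units; within the scatter). For compound 4 the estimated value is 9000 nM, with an expected range of 4000 nM to 20000 nM.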

Compound 4, half-maximal inhibitory concentration: 70 nM
Compound 4: middle estimate off by 130-fold (2.11 log units), on the high side; the measured number lies below the stated range.
By their numbers in this assay, from the lowest: compound 4; then compounds 3, 1 and 2 (each within the scatter of the next, the first and the last beyond it).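

In this assay, the phenyl group on a double-bonded chain carbon bound to a double-bonded chain carbon proves a far stronger lever than the earlier exchanges indicated, since 2,3,4-trimethoxyphenyl in place of 2,5-dimethoxyphenyl gives a 100-fold lower number from compound 3 to compound 4 (2.02 log units; beyond the scatter) and the largest step among the first three compounds was only modest. The gain also holds against the other two phenyl groups, with a 170-fold lower number from compound 1 to compound 4 (2.23 log units; beyond the scatter) and a 330-fold lower number from compound 2 to compound 4 (2.52 log units; beyond the scatter), so compound 4 is the most potent of the four here, and methoxy groups alone do not account for this, as compound 3 also carries them yet shows a 1.6-fold lower number from compound 1 to compound 3 (0.22 log units; within the scatter). No measurement shown here explains the size of this step.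

On these data alone, whether all three methoxy groups of 2,3,4-trimethoxyphenyl are needed stays open, as does whether a hydroxy group, an ethoxy group or an amine could stand in for any of them. As far as these compounds go, the shared core is the same in all four compounds, so it also stays open whether the step would carry over to a different core.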